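Trimming the hydroxycarbamoyl chain at compound 2

A few compounds are considered here, and "the series" means these few. Any claim that something is new, unique, unknown or untested is made for them only; others in the source may bear on it.

In a functional assay on CCRF-CEM cells (Homo sapiens) for inhibition (on this read-out higher numbers stand for weaker inhibition and lower numbers for stronger inhibition), compound 1 (`O=C(CCCCC[S+]([O-])c1ccccc1)NO`) reads > 25000 nM, which is a limit of the assay and not a number. Among the compounds with values here, compound 2 (`O=C(CCCCCC[S+]([O-])c1ccc(Cl)cc1)NO`) gives 12300 nM, the only actual number so far. Compound 3 (`O=C(CCCCC[S+]([O-])c1ccc(Cl)cc1)NO`) has not yet been measured. The change is hydroxycarbamoyl in place of (hydroxycarbamoyl)methyl on a saturated chain carbon, five bonds along the chain from a sulfur. No measured step sizes this change, so the expectation rests on compound 2 at 12300 nM alone. The expected change is a 1.6-fold higher number from compound 2 to compound 3 (0.21 log units; within the scatter), a small move towards weaker inhibition that is not clearly beyond the scatter. A reading that returns only a limit remains quite possible. For compound 3 the estimate is 20000 nM, with an expected range from 10000 nM to 38000 nM.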

Compound 3, half-maximal inhibitory concentration: 2600 nM
Compound 3: middle estimate off by 7.7-fold (0.89 log units), on the high side, and the stated range ends above it.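

In this assay, the chain length at this position proves to matter: hydroxycarbamoyl in place of (hydroxycarbamoyl)methyl gives a 4.7-fold lower number from compound 2 to compound 3 (0.67 log units; beyond the scatter), a shift towards stronger inhibition that compound 2 alone could not reveal. Within the data shown here, with the shorter chain held fixed, chloro in place of hydrogen on an aromatic carbon gives an at least 9.6-fold lower number from compound 1 to compound 3 (0.98 log units; beyond the scatter), the first sizing of that change. Compound 1 reads only as a limit, so this step has a floor and no exact size: the limit of > 25000 nM in this assay, at which 1 of the 3 values shown sits.

The compounds shown leave open whether a still shorter chain extends this gain or reverses it, and where a longer chain than that of compound 2 would fall. Also open, as far as these compounds go, is whether fluoro or methoxy in place of the chloro would give a comparable step.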